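Notes on an amide-to-sulfonamide change at a ring nitrogen

The source may hold more compounds than are shown below. What is called first, only, known or untested is meant among the compounds shown, and "the series" means these compounds.

Measured so far, in a physicochemical assay for lipophilicity, at pH 7.4; on this read-out higher numbers stand for higher lipophilicity and lower numbers for lower lipophilicity:
- compound 1 `Cc1ccc(NS(=O)(=O)c2ccc3c(c2)C(=O)CC(C2CCOCC2)O3)c(C)c1`: compound 1 gives 2.75
- compound 2 `CCc1ccc(N(CC(C)C)S(=O)(=O)c2ccc3c(c2)C(=O)CC(C2CCN(C(=O)C4CCCC4)CC2)O3)cc1`: compound 2 gives 5.13
- compound 3 `CCc1ccc(N(CC(C)C)S(=O)(=O)c2ccc3c(c2)C(=O)CC(C2CCOCC2)O3)cc1`: compound 3 gives 4.21

Compound 2 stands highest of the three numbers in this assay. The nearest is compound 3, whose number is lower by more than the scatter; compound 1 lies furthest, well below. Compound 4 `CCc1ccc(N(CC(C)C)S(=O)(=O)c2ccc3c(c2)C(=O)CC(C2CCN(S(=O)(=O)C4CCCC4)CC2)O3)cc1` is not yet measured. It differs from compound 2 in one place: cyclopentylsulfonyl in place of cyclopentylcarbonyl on an amine nitrogen in a ring. Going by the values given here, no step between measured compounds mirrors this change, so the expectation rests on compound 2 alone. The step from compound 2 to compound 4 is expected to be small, a number 0.07 log units higher from compound 2 to compound 4 (within the scatter), not beyond the scatter in either direction. Compound 4 is thus estimated at 5.2, within 4.6 to 5.8.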

Compound 4, distribution coefficient: 4.75
For compound 4 the middle estimate is 0.45 log units above the measured one; low and high end bracket the measured number.
By their numbers in this assay, from the lowest: compound 1; then compound 3; then compound 4; then compound 2.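

In this assay, cyclopentylsulfonyl in place of cyclopentylcarbonyl on an amine nitrogen in a ring gives a number 0.38 log units lower from compound 2 to compound 4 (beyond the scatter) and so this position does register the swap, even with the cyclopentyl ring kept on both sides. The entering group brings sulfur and a second hydrogen-bond acceptor, but this single pair cannot separate their contributions. Nothing available here explains the size or direction of the step.

As far as these compounds go, whether the same step appears with another group on this nitrogen remains open. A matched methylsulfonyl and acetyl pair would test this, as would a longer chain in place of cyclopentyl.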